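The source may report more compounds than this note shows. Statements on the series, on what has been measured and on what is new or still open speak of the compounds shown alone.

Compound 3 `COc1ccc(OC)c(COc2cc(NC(=O)c3ccc(I)cc3)ccc2N(C)S(C)(=O)=O)c1` sits at the lowest number of the three compounds measured in a functional assay on SK-BR-3 cells (Homo sapiens) for antiproliferative activity, read by MTT assay, with a stated time of 48 h (on this read-out lower numbers stand for stronger inhibition and higher numbers for weaker inhibition), where compound 3 gives 1.21 nM. Among the compounds with values here, its nearest neighbour is compound 2 `COc1ccc(C(=O)Nc2ccc(N(C)S(C)(=O)=O)c(OCc3cc(OC)ccc3OC)c2)cc1`, which in this assay gives 2.56 nM; the only single-point step recorded is a 2.1-fold lower number from compound 2 to compound 3 (0.33 log units; beyond the scatter), iodo in place of methoxy on an aromatic carbon. Compound 1 `CN(c1ccc(NC(=O)c2ccc3ccccc3c2)cc1OCc1cc(Cl)ccc1Cl)S(C)(=O)=O` gives 2210 nM, but it differs from compound 3 in two places, so its number says nothing exact about either change. Compound 4 `COc1ccc(OC)c(COc2cc(NC(=O)c3ccc4ccccc4c3)ccc2N(C)S(C)(=O)=O)c1` is reached by naphthalen-2-yl in place of 4-iodophenyl on a carbonyl carbon. Within the data shown here, no measured step covers this change; the iodo-for-methoxy step was modest, so compound 4 is expected to change by a 2.5-fold higher number from compound 3 to compound 4 (0.39 log units; beyond the scatter), most likely toward a somewhat higher number. The estimate for compound 4 in this assay is 3 nM, between 0.8 nM and 12 nM.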

Compound 4, half-maximal inhibitory concentration: 16.6 nM
Compound 4: the middle estimate sits 5.5-fold (0.74 log units) below what was measured; the measured number lies above the stated range.
By their numbers in this assay, from the lowest: compound 3; then compound 2; then compound 4; then compound 1.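

In this assay the group on the carbonyl carbon proves a sensitive position: naphthalen-2-yl in place of 4-iodophenyl brings a 14-fold higher number from compound 3 to compound 4 (1.14 log units; beyond the scatter) and in place of 4-methoxyphenyl brings a 6.5-fold higher number from compound 2 to compound 4 (0.81 log units; beyond the scatter) as a smaller rise. With naphthalen-2-yl held fixed, 2,5-dimethoxyphenyl in place of 2,5-dichlorophenyl brings a 130-fold lower number from compound 1 to compound 4 (2.12 log units; beyond the scatter) and is the largest of these steps. Nothing available explains these differences.

Open, from the compounds shown here alone, is how an amine or a carboxylic acid in place of the iodo would read. Also open, going by these compounds, is whether 4-iodophenyl would give a similar gain alongside 2,5-dichlorophenyl.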